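Four Analogues Held at the Cytotoxicity Limit

This account rests on a few compounds, and the source may have more. Where it says the series, first, only, none or still open, it means among the compounds named here.

Compound 1 `Cc1nc(C(NC(=O)C(=O)Nc2ccc(Cl)cc2)C2CCCCN2)sc1CO`, compound 2 `Cc1nc(C(NC(=O)C(=O)Nc2ccc(F)c(F)c2)C2CCCCN2)sc1CO` and compound 3 `Cc1nc(C(NC(=O)C(=O)Nc2ccc(F)c(F)c2)C2CCCCN2)sc1CCO` were examined in an ADME assay on MT2 cells (Homo sapiens) for cytotoxicity, read by XTT assay, with a stated time of 4 days; on this read-out higher numbers stand for lower toxicity in this test and lower numbers for higher toxicity in this test. In this assay compound 1 gives a value that is a limit of the assay, > 108000 nM. For compound 2 the result in this assay is likewise a limit, > 87000 nM. Compound 3 too reaches only a limit in this assay, > 78200 nM. Compound 2 differs from compound 1 by 4-chlorophenyl in place of 3,4-difluorophenyl on an amide-type nitrogen, and the step is a step that the two limits leave unreadable from compound 2 to compound 1. The cores of compound 2 and compound 3 differ by hydroxymethyl in place of hydroxy on a saturated chain carbon bound to an aromatic carbon, with a step that the two limits leave unreadable from compound 2 to compound 3. Compound 4 `Cc1nc(C(NC(=O)C(=O)Nc2ccc(Cl)cc2)C2CCCCN2)sc1CCO` is not yet measured; it differs from compound 3 by 4-chlorophenyl in place of 3,4-difluorophenyl on an amide-type nitrogen, the same change as between compound 2 and compound 1, made at the same place. That change has already been made once, giving a step that the two limits leave unreadable from compound 2 to compound 1. Compound 3 itself sits at a limit, > 78200 nM. On that footing compound 4 is expected to show a step that the limit leaves unreadable from compound 3 to compound 4, most likely as a further limit. Compound 4 is therefore estimated at 100000 nM, between 50000 nM and 200000 nM.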

Compound 4, half-maximal cytotoxic concentration: > 62000 nM
Compound 4 gave a limit, no number; the forecaster's own chance of this, stated with the estimate: 90%; the middle value is on the limit's open side.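

Among the compounds shown here, compound 4, like compound 1 and compound 3, gave only a limit in this assay, so no step to either neighbour can be read. What the compounds shown leave open is how far any of these four analogues lies from a measurable cytotoxic concentration.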